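Aryl ether to aryl thioether on the shared core

This account rests on a few compounds, and the source may have more. Where it says the series, first, only, none or still open, it means among the compounds named here.

The series rests on the core of compound 1 `Nc1cc(N)c2nc(-c3ccccc3)c(Oc3ccc(Cl)c(Cl)c3)nc2c1` and is read in a functional assay on HCT-116 cells (Homo sapiens) for inhibition, read by sulforhodamine B assay, with a stated time of 48 h (a lower number here means a stronger inhibitor of growth, a higher number a weaker inhibitor of growth), where compound 1 gives 15800 nM. Compound 2 `CCOC(=O)[C@H](CCC(=O)O)NC(=O)c1ccc(Oc2nc3cc(N)cc(N)c3nc2-c2ccccc2)cc1` gives 15100 nM in this assay. Of the two numbers recorded, compound 1 carries the larger figure, but the gap to compound 2 is within the scatter and carries no ranking; the two compounds cannot be set apart on these data. Going by these compounds, compound 3 `Nc1cc(N)c2nc(-c3ccccc3)c(Sc3ccc(F)cc3)nc2c1` is untested. It differs from compound 1 by (4-fluorophenyl)sulfanyl in place of 3,4-dichlorophenoxy on an aromatic carbon. For the measured compounds named here, no measured pair isolates this exchange, so its effect has to be guessed from the two values alone. Both measured numbers sit in the same region and the remainder of the molecule is unchanged, so no step beyond the scatter is expected in either direction. Compound 3 is therefore estimated at 14000 nM, within 4000 nM to 50000 nM, which means an expected step of a 1.1-fold lower number from compound 1 to compound 3 (0.05 log units; within the scatter).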

Compound 3, concentration for 50% growth inhibition: 14800 nM
For compound 3 the middle estimate is 1.1-fold (0.02 log units) below the measured one; low and high end bracket the measured number.
By their numbers in this assay, from the lowest: compounds 3, 2 and 1 (each within the scatter of the next).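

With (4-fluorophenyl)sulfanyl in place of 3,4-dichlorophenoxy on the aromatic carbon next to the ring nitrogen and ortho to the phenyl group, this assay gives a 1.1-fold lower number from compound 1 to compound 3 (0.03 log units; within the scatter). For the compounds shown here, this is the first pair that isolates a single place, and it shows that this aromatic carbon can take a sulfur-linked 4-fluorophenyl group in place of an oxygen-linked 3,4-dichlorophenyl group with no change beyond the scatter. The exchange alters the linking atom and the halogens on the ring together, and no reason for the flat result can be offered, as no supporting evidence bears on it.

Because both parts changed at once, the pair cannot show whether the linking atom and the ring halogens each have no effect or whether opposing effects cancel; a 4-fluorophenoxy group at this carbon would separate the two. Going by these compounds, it also remains open whether an amine in place of the linking atom, or a longer chain between the shared core and the aryl ring, would move the number beyond the scatter.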